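The compounds below may be only part of what the source reports. "The series", "measured", "known", "first", "only" and "open" are said of these compounds alone.

Working notes on the series. Compound 3 `Cc1ccc2[nH]c(=O)c(CN(Cc3ccc(C(C)(C)C)cc3)[C@H](C)c3ccc(F)cc3)cc2c1` stands at a limit rather than a number in a toxicity assay on MDCK cells (Canis lupus familiaris) for cytotoxicity, read by crystal violet staining, with a stated time of 48 h; a higher number here means that more compound is tolerated, a lower number that less compound is tolerated: compound 3 gives > 5000 nM. Compound 1 `CCc1ccc2[nH]c(=O)c(CN(Cc3ccc(C(C)(C)C)cc3)[C@H](CO)c3ccccc3)cc2c1` also sits at a limit in this assay, where compound 1 gives > 10000 nM. Compound 2 `CCc1ccc2[nH]c(=O)c(CN(Cc3ccc(C(C)(C)C)cc3)[C@@H](C)c3ccc(F)cc3)cc2c1` likewise sits at a limit in this assay, compound 2 giving > 5000 nM. Among the measured compounds shown here, the only measured step in the set, a step that the two limits leave unreadable from compound 1 to compound 2, cannot be read as a size, because both of its ends are limits; what the measurements show is merely that one value sits at the limit of > 10000 nM in this assay, at which 1 of the 3 values shown sits, and two sit at the limit of > 5000 nM in this assay, at which 2 of the 3 values shown sit.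

Compound 4 `CCc1ccc2[nH]c(=O)c(CN(Cc3ccc(C(C)(C)C)cc3)[C@H](C)c3ccc(F)cc3)cc2c1` differs from compound 3 by methyl in place of hydrogen on a saturated chain carbon bound to an aromatic carbon; cut one bond further out this reads methyl to ethyl on the shared core. For the measured compounds named here, no measured step in this assay touches that part of the molecule, so none bears on it directly, and the one step that exists is unreadable and offers no size to carry over. With all three measured values sitting at limits in this assay, no step beyond the scatter is expected in either direction, the expected step being a step that the limit leaves unreadable from compound 3 to compound 4. Compound 4 is therefore estimated at 10000 nM in this assay, within 5000 nM to 30000 nM, most likely reported again as a limit.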

Compound 4, half-maximal cytotoxic concentration: > 5000 nM
Compound 4: no number, only a limit; the forecaster's own chance of this, stated with the estimate: 80%; the middle value does not contradict the limit.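

In this assay compound 4 gives > 5000 nM, which is a limit and not a number. The steps to compound 4 from compound 1, compound 2 and compound 3 cannot be read as sizes, since all have limits at both ends. The compounds shown leave open where any half-maximal cytotoxic concentration lies, and whether methyl to ethyl or the configuration as drawn changes it.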